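The compounds below may be only part of what the source reports. "The series", "measured", "known", "first", "only" and "open" are said of these compounds alone.

Compound 1 `COc1ccc(S(=O)(=O)N2CCc3cccc(-c4ccc(C#N)cc4)c32)cc1` is the compound with the lowest number in a functional assay on MKN-45 cells (Homo sapiens) for inhibition, with a stated time of 72 h (on this read-out higher numbers stand for weaker inhibition and lower numbers for stronger inhibition), where compound 1 gives 17.2 nM. Compound 2 `COc1ccc(S(=O)(=O)N2CCc3cccc(-c4c(F)c(F)c(F)c(F)c4F)c32)cc1` gives 1780 nM in this assay, a value far beyond the scatter above that of compound 1, so compound 1 stands clearly apart on the numbers shown. Compound 3 `COc1ccc(S(=O)(=O)N2CCc3cccc(-c4ccncc4)c32)cc1` has not yet been measured; it differs from compound 1 by pyridin-4-yl in place of 4-cyanophenyl on an aromatic carbon. For the measured compounds named here, no measured pair shows this change, so the expectation rests on compound 1 alone: a moderate rise in the number is expected, a 4.7-fold higher number from compound 1 to compound 3 (0.67 log units; beyond the scatter). For compound 3 the estimated value in this assay is 80 nM, within a range of 20 nM to 400 nM.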

Compound 3, half-maximal inhibitory concentration: 69.5 nM
For compound 3 the middle estimate is 1.2-fold (0.06 log units) above the measured one; the measured number falls inside the stated range.
By their numbers in this assay, from the lowest: compound 1; then compound 3; then compound 2.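

In this assay replacing 4-cyanophenyl with pyridin-4-yl gives a 4.0-fold higher number from compound 1 to compound 3 (0.61 log units; beyond the scatter) and so costs only modestly at this aromatic carbon. A nitrile is thus not required here for a number in this lower range, although compound 1 remains ahead of compound 3. Nothing shown accounts for the size of this step.
The change removes the nitrile and puts a nitrogen into the ring at once, so the compounds shown do not separate the two, which unsubstituted phenyl could begin to do. On these data alone, how a saturated amine such as piperidin-4-yl or a benzoic acid would read at this place also stays open.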